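Moving the methylsulfonyl group on a piperidine benzamide

A few compounds are considered here, and "the series" means these few. Any claim that something is new, unique, unknown or untested is made for them only; others in the source may bear on it.

Measured compounds:
Compound 1 `O=C(c1ccc(OC(F)(F)F)cc1)N1CCC(N(C2CC2)S(=O)(=O)c2cccc(C(F)(F)F)c2)CC1`: 88%
Compound 2 `CS(=O)(=O)c1cccc(C(=O)N2CCC(N(C3CC3)S(=O)(=O)c3cccc(C(F)(F)F)c3)CC2)c1`: "not determined" (no result reported)

Compound 1 `O=C(c1ccc(OC(F)(F)F)cc1)N1CCC(N(C2CC2)S(=O)(=O)c2cccc(C(F)(F)F)c2)CC1` was tested in an assay on cells for inhibition of Voltage-dependent L-type calcium channel subunit alpha-1C (Homo sapiens), read by FLIPR and calcium flux, tested at 3 uM (a higher number here means a stronger effect of the compound at the concentration tested, a lower number a weaker effect), and gives 88%. Compound 2 `CS(=O)(=O)c1cccc(C(=O)N2CCC(N(C3CC3)S(=O)(=O)c3cccc(C(F)(F)F)c3)CC2)c1` shares the core of compound 1 and carries a 3-(methylsulfonyl)phenyl on the carbonyl carbon; in this assay compound 2 gives "not determined" (no result reported), so no single number stands for it and there is no anchor against which a change can be sized.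

Compound 3 `CS(=O)(=O)c1ccccc1C(=O)N1CCC(N(C2CC2)S(=O)(=O)c2cccc(C(F)(F)F)c2)CC1` is the next compound and has yet to be measured. It differs from compound 2 in one place: 2-(methylsulfonyl)phenyl in place of 3-(methylsulfonyl)phenyl on a carbonyl carbon. The two compounds have the same atoms, joined differently, the change sitting on a carbonyl carbon whose other neighbour is an amide-type nitrogen in a ring.

Among the measured compounds shown here, because compound 2 gives "not determined" (no result reported), no step from compound 2 to compound 3 can be assigned a size or a direction in this assay. For the measured compounds named here, the only measured reference is compound 1, and its value of 88% comes from a different group on the carbonyl carbon. Compound 3 is therefore expected to give about 65% in this assay, within an estimated range from 25% to 95%.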

Compound 3, a percentage reported as inhibition, at one concentration (the size of the read-out at that concentration, not a potency): 39%
For compound 3 the middle estimate is 26 percentage points above the measured one; the range from low to high includes it.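

In this assay, among the compounds shown here, the group on the carbonyl carbon proves able to shift the read-out on an otherwise unchanged core: 2-(methylsulfonyl)phenyl in place of 4-(trifluoromethoxy)phenyl gives a number 49 percentage points lower from compound 1 to compound 3 (beyond the scatter), the first measured change at this place and one that lies beyond the usual scatter. The step from compound 2 to compound 3 cannot be read, so moving the methylsulfonyl group on the phenyl ring still has neither a size nor a direction, and the comparison with compound 1 changes both the substituent and where it sits, without separating the two. Nothing measured on these compounds speaks to why the read-out changes at this place.

The compounds shown leave open whether the lower value goes with the methylsulfonyl group itself or with its place on the phenyl ring. They also leave open how this assay would read with an unsubstituted phenyl on the carbonyl carbon, or with a carboxylic acid or an amine on the phenyl ring in place of the methylsulfonyl group.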